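A few compounds are considered here, and "the series" means these few. Any claim that something is new, unique, unknown or untested is made for them only; others in the source may bear on it.

In a functional assay on Ca-Ski cells (Homo sapiens) for antiproliferative activity, with a stated time of 48 h (on this read-out higher numbers stand for weaker inhibition and lower numbers for stronger inhibition), compound 1 (`COc1ccc(C(=O)/C=C/c2ccccc2)c(O)c1Br`) gives > 50000 nM as a limit and not a number. Compound 2 (`COc1cc(O)c(C(=O)/C=C/c2ccccc2)cc1I`) gives > 50000 nM as a limit too. Compound 3 (`COc1cc(O)c(C(=O)/C=C/c2ccccc2)cc1Br`) likewise gives > 50000 nM as a limit. The set shows the limit of > 50000 nM in this assay, at which 3 of the 3 values shown sit, and so gives compound 1 no numerical rank. Compound 4 (`COc1ccc(C(=O)/C=C/c2ccccc2)c(O)c1I`) differs from compound 1 by a single exchange (iodo in place of bromo on an aromatic carbon) on the shared core. Going by the values given here, the only measured step of this kind is the reverse exchange (a step that the two limits leave unreadable from compound 2 to compound 3) with no readable size, so no step beyond the scatter is expected in this assay in either direction. The estimate is a number no higher from compound 1 to compound 4 (the limit leaves the size open) for this change. Compound 4 is estimated at 50000 nM with a range from 25000 nM to 100000 nM and may well give only a limit.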

Compound 4, half-maximal inhibitory concentration: > 50000 nM
Compound 4: a limit, no number; the forecaster's own chance of this, stated with the estimate: 75%; the middle value sits exactly at the limit.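

The step from compound 1 to compound 4 cannot be read, as both compounds give only a limit and not a number: the limit of > 50000 nM in this assay, at which 4 of the 4 values shown sit. The compounds shown leave open how strongly any of them inhibits in this assay, and whether iodo and bromo differ there at all.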